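This account rests on a few compounds, and the source may have more. Where it says the series, first, only, none or still open, it means among the compounds named here.

Measured so far in a functional assay on MCF7 cells (Homo sapiens) for cytotoxicity, read by MTT assay, with a stated time of 48 h; on this read-out higher numbers stand for weaker inhibition and lower numbers for stronger inhibition:
- compound 1 `CCCCCCCCCCCCCCCCCCNC(=O)[C@@H](N)[C@@H](C)O`: 27400 nM
- compound 2 `CCCCCCCCCCCCNC(=O)[C@@H](NC(=O)c1ccco1)[C@@H](C)O`: 67500 nM

Compound 2 holds the highest of the two numbers in this assay; compound 1 is the nearest, with a lower value, and that gap lies beyond the scatter.

Compound 3 `CCCCCCCCCCCCNC(=O)[C@@H](NC(=O)/C=C/c1ccccc1)[C@@H](C)O` differs from compound 2 by 2-phenylethenyl in place of furan-2-yl on a carbonyl carbon. Within the data shown here, no measured pair spans this change, so its effect in this assay is undetermined. A modest step, or none beyond the scatter, is expected, with no direction assured. Compound 3 is estimated at 50000 nM (range 20000 nM to 130000 nM). This implies an expected 1.4-fold lower number from compound 2 to compound 3 (0.13 log units; within the scatter).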

Compound 3, half-maximal inhibitory concentration: > 200000 nM
Compound 3 gave a limit, no number; the forecaster's own chance of this, stated with the estimate: 15%; at least 4.0-fold (0.60 log units) between middle value and limit.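

In this assay, the group on the carbonyl carbon bonded to the amide-type nitrogen clearly affects the read-out: 2-phenylethenyl in place of furan-2-yl gives an at least 2.9-fold higher number from compound 2 to compound 3 (0.47 log units; beyond the scatter). On these data alone, the direction is toward weaker inhibition, and the true size of the step remains unknown. Compound 3 gives a limit, not a number: the limit of > 200000 nM in this assay, at which 1 of the 3 values shown sits.

The change swaps the ring and adds the double bond together, leaving their separate contributions open. A saturated 2-phenylethyl group or a benzoyl group at this place would separate the two.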